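Tert-butyl in place of chloro on the shared core

The source may hold more compounds than are shown below. What is called first, only, known or untested is meant among the compounds shown, and "the series" means these compounds.

In a functional assay on the whole organism (strain OF1) for inhibition, with Mus musculus as the target, with a stated time of 1 h (on this read-out lower numbers stand for an effect already at smaller amounts and higher numbers for an effect only at larger amounts of compound), compound 1 `CS(=O)(=O)Nn1c(=O)[nH]c2cc(Cl)ccc2c1=O` gives 23 mg/kg, which places it at the upper end of the range measured so far. It is level within the scatter with compound 3 `CCc1ccc2c(=O)n(NS(C)(=O)=O)c(=O)[nH]c2c1`, which gives 16 mg/kg. Compound 2 `Cc1ccc2c(=O)n(NS(C)(=O)=O)c(=O)[nH]c2c1`, at 9 mg/kg, is the only clear departure, with a 2.6-fold lower number from compound 1 to compound 2 (0.41 log units; beyond the scatter).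

Compound 4 `CC(C)(C)c1ccc2c(=O)n(NS(C)(=O)=O)c(=O)[nH]c2c1` has tert-butyl in place of chloro on an aromatic carbon. Two measured replacements of that chloro bear on this change. The methyl case is modest, with a 2.6-fold lower number from compound 1 to compound 2 (0.41 log units; beyond the scatter), while the ethyl case gives a 1.4-fold lower number from compound 1 to compound 3 (0.16 log units; within the scatter) and stays within the scatter. The step between these two alkyl groups, a 1.8-fold higher number from compound 2 to compound 3 (0.25 log units; within the scatter), is also within the scatter, so it sets no firm direction. Even so, the ethyl result suggests that the gain seen with methyl need not carry over to a further alkyl group. No branched group has been measured, which leaves the expectation loose.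

The estimated change is a 1.0-fold higher number from compound 1 to compound 4 (0.02 log units; within the scatter), so no step beyond the scatter is expected. For compound 4 the expected value is 24 mg/kg, with an estimated range from 11 mg/kg to 55 mg/kg.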

Compound 4, dose for half-maximal effect: 29.5 mg/kg
For compound 4 the middle estimate is 1.2-fold (0.09 log units) below the measured one; low and high end bracket the measured number.
By their numbers in this assay, from the lowest: compounds 2, 3, 1 and 4 (each within the scatter of the next, the first and the last beyond it).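

In this assay, the change from chloro to tert-butyl on this aromatic carbon leaves the read-out level, with a 1.3-fold higher number from compound 1 to compound 4 (0.11 log units; within the scatter), so a group of 4 heavy atoms with no hydrogen-bond donors or acceptors is accommodated here without a step beyond the scatter. Going by these compounds alone, the branched group also stays level with the ethyl group, with a 1.8-fold higher number from compound 3 to compound 4 (0.27 log units; within the scatter), but it is clearly separated from the methyl group, with a 3.3-fold higher number from compound 2 to compound 4 (0.52 log units; beyond the scatter), which is the first alkyl-to-alkyl step at this position to pass the scatter; compound 2 therefore stands apart from compound 4, while compound 3 lies within the scatter of both and fits no clean trend with alkyl size. Nothing in the available data gives a reason for this separation.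

The compounds shown leave open whether the lower number of compound 2 is particular to the methyl group or would also appear with a methoxy group, an amine or a carboxylic acid on this aromatic carbon. They also leave open how plain hydrogen at this place would compare with chloro and the three alkyl groups.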